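This account rests on a few compounds, and the source may have more. Where it says the series, first, only, none or still open, it means among the compounds named here.

Within a functional assay on the whole organism (plasma, strain Wistar) with Rattus norvegicus as the target, with a stated time of 15 days, at a dose of 30 mg/kg by the oral route (on this read-out higher numbers stand for a stronger effect at the one dose given and lower numbers for a weaker effect), compound 3, `O=C1NC(=O)/C(=C/c2ccc(OCCSc3nnc(Cc4ccccc4)o3)cc2)S1`, gives 19.1% and stands lowest of the three numbers in hand. Its nearest neighbour is compound 1, `O=C1NC(=O)/C(=C/c2ccc(OCCSc3nnc(-c4ccc(Br)cc4)[nH]3)cc2)S1`, which gives 19.5% in this assay, a number within the scatter of compound 3. The furthest is compound 2, `COc1ccc(-c2nnc(SCCOc3ccc(/C=C4\SC(=O)NC4=O)cc3)[nH]2)cc1`, which gives 40% in this assay, beyond the scatter of compound 3.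

Within the data shown here, the only single-point step measured is a number 20.5 percentage points higher from compound 1 to compound 2 (beyond the scatter), a modest step on the aryl group carried by the core of compound 1. The change that leads on to compound 4, `O=C1NC(=O)/C(=C/c2ccc(OCCSc3nnc(-c4ccncc4)o3)cc2)S1`, is of a different kind: pyridin-4-yl in place of benzyl on an aromatic carbon. Among the measured compounds shown here, no measured pair shows a pyridin-4-yl entering, nor a benzyl leaving, so the one measured step does not bear directly on it; it shows only that a change at the group on the five-membered ring can move this assay by a modest amount. With nothing pointing in either direction, compound 4 is expected to sit close to compound 3, the step of a number 4.9 percentage points higher from compound 3 to compound 4 (within the scatter) being estimated within the scatter. The estimate for compound 4 in this assay is 24%, with a range from 10% to 40%.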

Compound 4, a percentage reported as activity, at one dose (the size of the read-out at that dose, not a potency): 40%
For compound 4 the middle estimate is 16 percentage points below the measured one; low and high end bracket the measured number.
By their numbers in this assay, from the lowest: compounds 3 and 1 (each within the scatter of the next); then compounds 2 and 4 (each within the scatter of the next).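

In this assay, the step is a number 20.9 percentage points higher from compound 3 to compound 4 (beyond the scatter), so the aromatic carbon of the five-membered aromatic ring with 2 nitrogen and 1 oxygen does respond to a change of group on the shared core, which the earlier step on the core of compound 1 could not show for this ring. The step comes from a single exchange that alters several things at once: benzyl leaves with its carbon-only aromatic ring and no hydrogen-bond acceptor, and pyridin-4-yl enters with a ring nitrogen and 1 hydrogen-bond acceptor, with the ring now attached directly to the five-membered ring. Among these compounds, nothing at hand measures why the number moves at this position, and the single pair cannot assign the step to any one of these differences.

The compounds shown leave open how a plain phenyl at this carbon would read, which would separate the loss of the benzyl methylene link from the entry of the ring nitrogen. Also open, on these data alone, is whether pyridin-3-yl, or a phenyl carrying an amine or a carboxylic acid, would hold the higher number.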